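Terminal acid, acetate and methyl ester on the side chain

The compounds below may be only part of what the source reports. "The series", "measured", "known", "first", "only" and "open" are said of these compounds alone.

Compound 2 `C=C1CC[C@@H]2[C@](C)(CCC[C@]2(C)C(=O)O)[C@H]1CC/C(C)=C/C(=O)O` stands at the high end of the two numbers obtained so far in a functional assay on cells (Mus musculus) for cytotoxicity, read by MTT assay, with a stated time of 24 h (on this read-out lower numbers stand for an effect already at smaller amounts and higher numbers for an effect only at larger amounts of compound), where compound 2 gives 95.9 ug/mL. Its only comparator, compound 1 `C=C1CC[C@@H]2[C@](C)(CCC[C@]2(C)C(=O)O)[C@H]1CC/C(C)=C/COC(C)=O`, gives 73.3 ug/mL in this assay. Going by the values given here, the single measured step, a 1.3-fold higher number from compound 1 to compound 2 (0.12 log units; within the scatter), means that replacing acetoxymethyl by carboxy at the chain terminus did not move the read-out beyond the scatter, so the two compounds cannot be ordered.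

Compound 3 `C=C1CC[C@@H]2[C@](C)(CCC[C@]2(C)C(=O)O)[C@H]1CC/C(C)=C/C(=O)OC` differs from compound 2 by methyl in place of hydrogen on an oxygen next to a carbonyl group, so carboxy becomes methoxycarbonyl. Among the compounds with values here, the only step that bears on this position is the one from compound 1 to compound 2, and it was small; an acetate ester and a free acid gave indistinguishable numbers. On that basis no step beyond the scatter is expected for the methyl ester either, and the change from compound 2 to compound 3 is estimated at a 1.1-fold lower number from compound 2 to compound 3 (0.03 log units; within the scatter) in this assay. Compound 3 is therefore expected to give 90 ug/mL in this assay, with a range from 45 ug/mL to 180 ug/mL.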

Compound 3, concentration for half-maximal effect: > 100 ug/mL
Compound 3 was reported as a limit; the forecaster's own chance of this, stated with the estimate: 5%; at least 1.1-fold (0.04 log units) between middle value and limit.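

For compound 3 in this assay, > 100 ug/mL is a limit of the assay and not a number. Turning the free acid into the methyl ester gives an at least 1.0-fold higher number from compound 2 to compound 3 (0.01 log units; that floor lies within the scatter), and moving from the acetate terminus to methoxycarbonyl gives an at least 1.3-fold higher number from compound 1 to compound 3 (0.13 log units; that floor lies within the scatter); both are only floors and both lie within the scatter, so acetate, acid and methyl ester are not separated, and the true size of either step remains unknown. New at this position is a terminus whose read-out no longer resolves to a number, so the series here ends in a limit rather than a third comparable value: the limit of > 100 ug/mL in this assay, at which 1 of the 3 values shown sits.

Still open, from the compounds shown here alone, is how far the methyl ester really lies from the acid, since the limit conceals that distance, and what a primary amide, an amine or a longer chain at the terminus would give in this assay. Going by these compounds, the carboxylic acid on the shared core is the same in all three compounds, so its contribution to the read-out also remains open.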